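Swapping the Branched Chain for a Butylbenzyl Group

The source may hold more compounds than are shown below. What is called first, only, known or untested is meant among the compounds shown, and "the series" means these compounds.

Compound 3 `CCCCC(CCCC)n1ccc2cc(/C(C)=C/C(=O)Nc3ccccc3OCCCC(=O)O)ccc21` gives 21 nM in an assay on Prostate gland for inhibition of steroid 5-alpha-reductase (Rattus norvegicus) (a lower number here means a stronger inhibitor, a higher number a weaker inhibitor), the lowest of the three numbers measured. Compound 2 `CCCCCn1ccc2cc(/C(C)=C/C(=O)Nc3ccccc3OCCCC(=O)O)ccc21` gives 23 nM, and a 1.1-fold lower number from compound 2 to compound 3 (0.04 log units; within the scatter), so the two lie within the scatter of each other. Compound 1 `CCCn1ccc2cc(/C(C)=C/C(=O)Nc3ccccc3OCCCC(=O)O)ccc21` gives 190 nM, and a 9.0-fold lower number from compound 1 to compound 3 (0.96 log units; beyond the scatter). Compound 4 `CCCCc1ccc(Cn2ccc3cc(/C(C)=C/C(=O)Nc4ccccc4OCCCC(=O)O)ccc32)cc1` differs from compound 3 by 4-butylbenzyl in place of 1-butylpentyl on an aromatic nitrogen. Of the measured steps, an 8.3-fold lower number from compound 1 to compound 2 (0.92 log units; beyond the scatter) was beyond the scatter, whereas a 1.1-fold lower number from compound 2 to compound 3 (0.04 log units; within the scatter) stayed within it. Within the data shown here, no measured step exchanges an alkyl group for a benzyl group on that nitrogen, so compound 4 is expected to move little: a 1.4-fold higher number from compound 3 to compound 4 (0.15 log units; within the scatter). Compound 4 is therefore estimated at 30 nM, between 8 nM and 110 nM.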

Compound 4, half-maximal inhibitory concentration: 100 nM
Estimate against measurement, compound 4: 3.3-fold (0.52 log units) below, within the range that was stated.
By their numbers in this assay, from the lowest: compounds 3 and 2 (each within the scatter of the next); then compounds 4 and 1 (each within the scatter of the next).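

In this assay, 4-butylbenzyl on the aromatic nitrogen gives the first rise beyond the scatter at this position, with a 4.8-fold higher number from compound 3 to compound 4 (0.68 log units; beyond the scatter) and also a 4.3-fold higher number from compound 2 to compound 4 (0.64 log units; beyond the scatter). Set against the propyl group, the same group brings no change beyond the scatter, with a 1.9-fold lower number from compound 1 to compound 4 (0.28 log units; within the scatter). No measurement given here bears on the reason for this rise. 

The compounds shown leave open whether the ring or the butyl group on it accounts for the rise. They also leave open how a plain benzyl group, or a benzyl group carrying an amine or a carboxylic acid, would compare.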